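Same Sulfonamide Swap Repeated on a Second Core

The compounds below may be only part of what the source reports. "The series", "measured", "known", "first", "only" and "open" are said of these compounds alone.

Compound 1 `O=c1oc2ccccc2c(Cl)c1/C=N/c1ccc(S(=O)(=O)Nc2nccs2)cc1` and compound 2 `N=C(N)NS(=O)(=O)c1ccc(/N=C/c2c(Cl)c3ccccc3oc2=O)cc1` share a core and differ in a single place. In a functional assay on B16-F10 cells (Mus musculus) for cytotoxicity, read by CCK-8 assay, with a stated time of 48 h (on this read-out higher numbers stand for weaker inhibition and lower numbers for stronger inhibition), compound 1 gives 300 nM, and compound 2 gives 180 nM. The change between them is a group of 3 heavy atoms (1 carbon, 2 nitrogen; no ring) in place of a group of 5 heavy atoms (3 carbon, 1 nitrogen, 1 sulfur; one five-membered aromatic ring with 2 hetero atoms), on a sulfonamide nitrogen and it brought a 1.7-fold lower number from compound 1 to compound 2 (0.22 log units; within the scatter). Compound 3 `CC(C)(C)c1cc(C(C)(C)C)c2oc(=O)c(/C=N/c3ccc(S(=O)(=O)Nc4nccs4)cc3)c(Cl)c2c1` has a different core; how its core differs from that of compound 1 is not broken down here. In this assay compound 3 gives 160 nM. Compound 4 `CC(C)(C)c1cc(C(C)(C)C)c2oc(=O)c(/C=N/c3ccc(S(=O)(=O)NC(=N)N)cc3)c(Cl)c2c1` is not yet measured and differs from compound 3 by a group of 3 heavy atoms (1 carbon, 2 nitrogen; no ring) in place of a group of 5 heavy atoms (3 carbon, 1 nitrogen, 1 sulfur; one five-membered aromatic ring with 2 hetero atoms), on a sulfonamide nitrogen, the same change made at the same place as from compound 1 to compound 2. Because the earlier step was a 1.7-fold lower number from compound 1 to compound 2 (0.22 log units; within the scatter), the expected step is a 1.5-fold lower number from compound 3 to compound 4 (0.16 log units; within the scatter), again within the scatter. Compound 4 is estimated at 110 nM in this assay, with a likely range from 45 nM to 270 nM.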

Compound 4, half-maximal inhibitory concentration: 250 nM
Compound 4: middle estimate off by 2.3-fold (0.36 log units), on the low side; the range from low to high includes it.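

In this assay replacing the 1,3-thiazol-2-yl group on a sulfonamide nitrogen gives a 1.6-fold higher number from compound 3 to compound 4 (0.19 log units; within the scatter) on the second core. On paper the two steps point in opposite directions, but neither step nor the gap between them stands out from the usual scatter: the same change on two cores in this assay, a 1.7-fold lower number (0.22 log units; within the scatter) from compound 1 to compound 2 and a 1.6-fold higher number (0.19 log units; within the scatter) from compound 3 to compound 4, 2.6-fold (0.42 log units) apart, within the scatter of two such steps. This shows no clear effect of the change on either core, and it neither shows that the change carries over from one core to the other nor that it behaves differently on each.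

The compounds shown leave open whether a different group on the sulfonamide nitrogen, such as a pyridine ring, an amine or a longer chain carrying a carboxylic acid, would shift the number beyond the scatter on these two cores.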